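The compounds below may be only part of what the source reports. "The series", "measured", "known", "first", "only" and "open" are said of these compounds alone.

Measured so far in a functional assay on HeLa cells (Homo sapiens) for cytotoxicity, read by cell counting, with a stated time of 4 days; on this read-out higher numbers stand for weaker inhibition and lower numbers for stronger inhibition:
- compound 1 `CC(C)(C)c1ccc(CN2C(=O)S/C(=C\c3cccc(N)c3)C2=O)cc1`: 145000 nM
- compound 2 `Nc1cccc(/C=C2\SC(=O)N(Cc3ccc(C(F)(F)F)cc3)C2=O)c1`: > 250000 nM

Compound 2 stands at the edge of what this assay reports: its value is a limit, not a number, as the limit of > 250000 nM in this assay, at which 1 of the 2 values shown sits, shows. Among the compounds with values here, the one measured step leads to it, an at least 1.7-fold higher number from compound 1 to compound 2 (0.23 log units; that floor lies within the scatter), and that step is within the scatter, so the two measured compounds cannot be ordered with confidence.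

Compound 3 `Nc1cccc(/C=C2\SC(=O)N(Cc3ccc(Cl)cc3)C2=O)c1` differs from compound 2 in one place: chloro in place of trifluoromethyl on an aromatic carbon. Within the data shown here, no measured step contains this exchange, so the only guide is how weakly both measured compounds act in this assay, with compound 1 already far up the scale and compound 2 at the limit. From that, no step beyond the scatter is expected in either direction from compound 2 to compound 3, and a fair chance remains that compound 3 will also come back only as a limit.

Compound 3 is therefore expected to give about 200000 nM, within a range from 80000 nM to 400000 nM. This estimate amounts to an at least 1.2-fold lower number from compound 2 to compound 3 (0.09 log units; that floor lies within the scatter).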

Compound 3, half-maximal inhibitory concentration: > 250000 nM
Compound 3 gave a limit, no number; the forecaster's own chance of this, stated with the estimate: 45%; middle value at least 1.2-fold (0.09 log units) from the limit.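

In this assay compound 3 also returns only a limit, > 250000 nM, and not a number. Against the tert-butyl group, chloro gives an at least 1.7-fold higher number from compound 1 to compound 3 (0.23 log units; that floor lies within the scatter), so this exchange does not order the two compounds with confidence, and the exchange of trifluoromethyl for chloro cannot be read at all, as both of its ends are limits. What is new is that a second, much smaller group at this place on the aromatic ring, a single chlorine atom where trifluoromethyl has 4 heavy atoms, also ends at the edge of the scale, so two different groups now share the same limit: the limit of > 250000 nM in this assay, at which 2 of the 3 values shown sit.

Among the compounds shown, only compound 1, with its tert-butyl group, gives an actual number, 145000 nM, so how far the read-out responds to this position stays open. A group such as an amine, a carboxylic acid or a longer chain like n-butyl at the same place could show whether any change here gives a number well clear of the limit.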